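Removing One Chloro Group From a Fused Core

The source may hold more compounds than are shown below. What is called first, only, known or untested is meant among the compounds shown, and "the series" means these compounds.

Three compounds share a fused two-ring core that carries chloro groups. Compound 1 `ClCc1ccccc1Cn1cnc2c(Cl)nc(Cl)nc21` carries two chloro groups on that core, while compound 2 `ClCc1ccccc1Cn1cnc2c(Cl)ncnc21` carries only one. Compound 3 `ClCc1ccc(Cn2cnc3nc(Cl)nc(Cl)c32)cc1` has the same atoms as compound 1, joined differently; the difference between the two cores is not broken down here. Compound 4 `ClCc1ccc(Cn2cnc3ncnc(Cl)c32)cc1` is compound 3 with one chloro group taken away.

In a functional assay on KM12 cells (Homo sapiens) for cytotoxicity, read by sulforhodamine B assay, with a stated time of 48 h (a higher number here means a weaker inhibitor of growth, a lower number a stronger inhibitor of growth), compound 1 gives 1470 nM, compound 2 gives 16600 nM, and compound 3 gives 260 nM, the lowest of the three numbers. The change from compound 1 to compound 2 hydrogen in place of chloro on an aromatic carbon produced an 11-fold higher number from compound 1 to compound 2 (1.05 log units; beyond the scatter). The change from compound 3 to compound 4 hydrogen in place of chloro on an aromatic carbon is the same change at the same place. Compound 4 is therefore expected to sit well above compound 3, with an estimated step of an 11-fold higher number from compound 3 to compound 4 (1.05 log units; beyond the scatter), because the same change gave an 11-fold higher number from compound 1 to compound 2 (1.05 log units; beyond the scatter). The estimate for compound 4 in this assay is 2900 nM, expected to fall between 1200 nM and 7000 nM.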

Compound 4, concentration for 50% growth inhibition: 1650 nM
For compound 4 the middle estimate is 1.8-fold (0.24 log units) above the measured one, within the range that was stated.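

In this assay, putting hydrogen in place of the chloro group on the core of compound 3 gives a 6.3-fold higher number from compound 3 to compound 4 (0.80 log units; beyond the scatter), so the rise in the number seen on the core of compound 1 appears on this second core too. Among the compounds shown here, the two steps point the same way and agree in size as closely as repeated measurements would allow, which means that the effect of this change carried over from one core to the other: the same change on two cores in this assay, an 11-fold higher number (1.05 log units; beyond the scatter) from compound 1 to compound 2 and a 6.3-fold higher number (0.80 log units; beyond the scatter) from compound 3 to compound 4, 1.8-fold (0.25 log units) apart, within the scatter of two such steps This agreement rests on only two pairs of compounds in a single cell assay, so it does not show that the change would behave the same way on any further core or in other cells, and it does not explain why the chloro group matters.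

From the compounds shown here alone, only chloro and hydrogen are compared at this place, so it remains open how an amine or a methoxy group there would fare. Also open, going by these compounds, is what would happen if the remaining chloro group on the core were replaced.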